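A few compounds are considered here, and "the series" means these few. Any claim that something is new, unique, unknown or untested is made for them only; others in the source may bear on it.

Of the compounds shown here, three built on a similar core have been tested so far in a functional assay on FaDu cells (Homo sapiens) for cytotoxicity, read by MTT assay, with a stated time of 72 h (a lower number here means that less compound is tolerated, a higher number that more compound is tolerated), to date. Compound 1 (`COc1ccc(NC(=O)C(=O)c2cn(C(C)C)c3ccccc23)nn1`) gives 2270 nM and stands highest of the two true numbers. Compound 3 (`CC(C)Oc1ccc(NC(=O)C(=O)c2cn(C(C)C)c3ccccc23)cn1`) gives 408 nM as a lower number, a gap beyond the usual scatter, yet it differs from compound 1 in more than one place, so the gap cannot be pinned on any single change. Compound 2 (`COc1ccc(NC(=O)C(=O)c2cn(CC(C)(C)OC)c3ccccc23)cn1`) is reported as > 10000 nM and this is a limit of the assay, not a number.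

Compound 4 (`COc1nsc(NC(=O)C(=O)c2cn(C(C)C)c3ccccc23)n1`) has not yet been measured. It keeps the core of compound 1 and carries 3-methoxy-1,2,4-thiadiazol-5-yl in place of 6-methoxypyridazin-3-yl on an amide-type nitrogen. One six-membered aromatic ring with 2 hetero atoms thus gives way to one five-membered aromatic ring with 3 hetero atoms. Going by the values given here, no measured pair shows this swap alone, so the expectation starts from compound 1 at 2270 nM as its anchor and needs a wide range. The step of a 1.3-fold lower number from compound 1 to compound 4 (0.10 log units; within the scatter) is expected to stay within the usual scatter. In this assay the estimate for compound 4 is 1800 nM with an expected range from 400 nM to 8000 nM around it.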

Compound 4, concentration lethal to 50% of the cells: 10400 nM
Beside the measured number, compound 4's estimate is 5.8-fold (0.76 log units) below it; measured number above the stated range.
By their numbers in this assay, from the lowest: compound 3; then compound 1; then compound 4.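

Exchanging 6-methoxypyridazin-3-yl for 3-methoxy-1,2,4-thiadiazol-5-yl on the amide-type nitrogen gives a 4.6-fold higher number from compound 1 to compound 4 (0.66 log units; beyond the scatter) in this assay, and it is the only change among these compounds that can be read on its own. The earlier compounds shown here could not show this, since they differ from one another in more than one place; here, with the rest of the molecule kept, the aromatic ring on this nitrogen alone moves the result beyond the scatter, towards more compound being tolerated, so this ring cannot be treated as freely exchangeable. Compound 2 carries a limit of the assay and not a number, and the result for compound 4 lies in the same region, so the upper end of the scale deserves caution: the limit of > 10000 nM in this assay, at which 1 of the 4 values shown sits.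

One step cannot separate what changes together here, namely the ring size, the number of hetero atoms and the arrival of sulfur. On these data alone, how a plain phenyl ring would behave on the same nitrogen stays open, as does the effect of a dimethylamino group or a carboxylic acid in place of the methoxy group on the ring.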